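The source may hold more compounds than are shown below. What is called first, only, known or untested is meant among the compounds shown, and "the series" means these compounds.

Compound 1 `Cc1cn([C@H]2C[C@H](SSC(Cl)(Cl)Cl)[C@@H](CO)O2)c(=O)[nH]c1=O` was characterised in a physicochemical assay for pharmacokinetics, at pH 7.2; on this read-out higher numbers stand for a longer-lived compound and lower numbers for a shorter-lived compound. In this assay compound 1 yields only a limit, < 0.0834 h. Its companion compound 2 `CCCCCCCCSS[C@H]1C[C@H](n2cc(C)c(=O)[nH]c2=O)O[C@@H]1CO` likewise yields only a limit in this assay, < 0.0834 h. The step that the two limits leave unreadable from compound 1 to compound 2 therefore carries no readable size, since both values sit at the limit of < 0.0834 h in this assay, at which 2 of the 2 values shown sit. Compound 3 `Cc1cn([C@H]2C[C@H](SSCCN)[C@@H](CO)O2)c(=O)[nH]c1=O` differs from compound 1 by 2-aminoethyl in place of trichloromethyl on a sulfur. For the measured compounds named here, no measured step speaks to this change with a readable size, so no direction beyond the scatter can be anticipated from the numbers in hand. Compound 3 is expected to show about 0.05 h, with a range from 0.015 h to 0.2 h, an expected step that the limit leaves unreadable from compound 1 to compound 3.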

Compound 3, half-life: < 0.0834 h
Compound 3 was reported as a limit; the forecaster's own chance of this, stated with the estimate: 70%; the middle value does not contradict the limit.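

Compound 3 also gives only a limit, so its steps from compound 1 and compound 2 cannot be read: the limit of < 0.0834 h in this assay, at which 3 of the 3 values shown sit. The compounds shown leave open whether the group on the sulfur changes the half-life in this assay at all.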